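Methyl Removal From a Biaryl in Growth Inhibition

A few compounds are considered here, and "the series" means these few. Any claim that something is new, unique, unknown or untested is made for them only; others in the source may bear on it.

The three measured compounds were tested in a toxicity assay on RMS13 cells (Homo sapiens) for inhibition, with a stated time of 24 h; a higher number here means a weaker inhibitor of growth, a lower number a stronger inhibitor of growth:

Compound 1, `CC1=C(C(=O)OCc2ccccc2)C(c2ccc(-c3ccccc3C)cc2)NC(=O)N1Cc1ccc(-c2nnn[nH]2)cc1`: 73000 nM
Compound 2, `CC1=C(C(=O)OCc2ccccc2)C(c2ccc(-c3ccccc3)cc2)NC(=O)N1Cc1ccc(-c2nnn[nH]2)cc1`: 96000 nM
Compound 3, `CC1=C(C(=O)OCc2ccccc2)C(c2ccc(-c3ccccc3C)cc2)NC(=S)N1CCCCCc1nnn[nH]1`: 100000 nM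

Compound 1 and compound 2 share a core and differ by hydrogen in place of methyl on an aromatic carbon. In this assay that change gave a 1.3-fold higher number from compound 1 to compound 2 (0.12 log units; within the scatter). How the core of compound 3 differs from that of compound 1 is not broken down here; compound 3 and compound 2 give values that lie close together.

Compound 4, `CC1=C(C(=O)OCc2ccccc2)C(c2ccc(-c3ccccc3)cc2)NC(=S)N1CCCCCc1nnn[nH]1`, has not yet been measured. It differs from compound 3 by hydrogen in place of methyl on an aromatic carbon, the same change as that between compound 1 and compound 2. The expected step from compound 3 to compound 4 is a 1.1-fold higher number from compound 3 to compound 4 (0.04 log units; within the scatter), resting on the earlier step of a 1.3-fold higher number from compound 1 to compound 2 (0.12 log units; within the scatter) and on compound 3 at 100000 nM. Compound 4 is therefore estimated to give about 110000 nM in this assay, with a likely range from 60000 nM to 200000 nM.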

Compound 4, concentration for 50% growth inhibition: 110000 nM
Compound 4: middle estimate and measured number agree at the digits printed; the range from low to high includes it.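

On the core of compound 3, the change from 2-methylphenyl to phenyl gave a 1.1-fold higher number from compound 3 to compound 4 (0.04 log units; within the scatter) in this assay. Set beside the earlier step, the change carries from one core to the other with no difference that can be told apart: the same change on two cores in this assay, a 1.3-fold higher number (0.12 log units; within the scatter) from compound 1 to compound 2 and a 1.1-fold higher number (0.04 log units; within the scatter) from compound 3 to compound 4, 1.2-fold (0.08 log units) apart, within the scatter of two such steps

Neither step lies beyond the scatter, so this is agreement between two steps too small to read as an effect, and it does not show that the methyl group matters on either core or that a rule holds across the series. The compounds shown leave open whether another group in that place, such as a chlorine, a methoxy or an amine, would shift the number beyond the scatter. They also leave open how the same change would behave on any further core.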